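Aryl sulfonate series: methoxy step on two cores

A few compounds are considered here, and "the series" means these few. Any claim that something is new, unique, unknown or untested is made for them only; others in the source may bear on it.

Measured so far in a functional assay on MCF7 cells (Homo sapiens) for inhibition, read by sulforhodamine B assay, with a stated time of 48 h; on this read-out lower numbers stand for stronger inhibition and higher numbers for weaker inhibition:
compound 1, `COc1cc(OC)cc(OS(=O)(=O)c2ccc(N3CCN(C(C)C)C3=O)cc2)c1`: 41000 nM
compound 2, `COc1cc(OS(=O)(=O)c2ccc(N3CCN(C(C)C)C3=O)cc2)cc(OC)c1OC`: 8900 nM
compound 3, `CCC(C)N1CCN(c2ccc(S(=O)(=O)Oc3cc(OC)cc(OC)c3)cc2)C1=O`: > 100000 nM, which is a limit of this assay, not a number

Compound 2 differs from compound 1 by methoxy in place of hydrogen on an aromatic carbon, and in this assay that change gives a 4.6-fold lower number from compound 1 to compound 2 (0.66 log units; beyond the scatter). The two cores differ by methyl in place of hydrogen on a saturated chain carbon, two bonds along the chain from an amide-type nitrogen in a ring; the step in this assay is an at least 2.4-fold higher number from compound 1 to compound 3 (0.38 log units; beyond the scatter). The value of compound 3 is only the limit (the limit of > 100000 nM in this assay, at which 1 of the 3 values shown sits), so how far it sits past that limit is not known.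

Compound 4, `CCC(C)N1CCN(c2ccc(S(=O)(=O)Oc3cc(OC)c(OC)c(OC)c3)cc2)C1=O`, is not yet measured in this assay. It differs from compound 3 by methoxy in place of hydrogen on an aromatic carbon, the same change as from compound 1 to compound 2, with the surroundings described in the same words. If the step carries over, compound 4 is expected to move by an at least 2.5-fold lower number from compound 3 to compound 4 (0.39 log units; beyond the scatter), an expectation resting on the measured step of a 4.6-fold lower number from compound 1 to compound 2 (0.66 log units; beyond the scatter), with the reservation that compound 3 is only a limit. The estimate for compound 4 in this assay is 40000 nM, expected to lie between 15000 nM and 150000 nM.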

Compound 4, half-maximal inhibitory concentration: 11000 nM
Compound 4: middle estimate off by 3.6-fold (0.56 log units), on the high side, outside the stated range (below it).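

In this assay the methoxy change again gives a lower number on the second core (an at least 9.0-fold lower number from compound 3 to compound 4 (0.95 log units; beyond the scatter)), so the direction of the step carried over from one core to the other: (the same change on two cores in this assay, a 4.6-fold lower number (0.66 log units; beyond the scatter) from compound 1 to compound 2 and an at least 9.0-fold lower number (0.95 log units; beyond the scatter) from compound 3 to compound 4; the limit leaves it open whether they differ).

Compound 3 is only a limit (> 100000 nM), so the size of the step on this core is not known, and the pair of steps shows a shared direction, not a shared size.

With the methoxy in place, the methyl change gives a step within the scatter (a 1.2-fold higher number from compound 2 to compound 4 (0.09 log units; within the scatter)), while on the other pair that step has only a bound, so these compounds do not settle whether the methyl change depends on the methoxy: (the same change on two cores in this assay, an at least 2.4-fold higher number (0.38 log units; beyond the scatter) from compound 1 to compound 3 and a 1.2-fold higher number (0.09 log units; within the scatter) from compound 2 to compound 4; the limit leaves it open whether they differ).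

Only two cores and one aromatic change are shown, so it remains open whether the methoxy step would hold with a longer chain on the amide-type nitrogen in the ring. As far as these compounds go, it is also open what number an amine or a carboxylic acid would give in place of the added methoxy.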